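The source may hold more compounds than are shown below. What is called first, only, known or untested is meant among the compounds shown, and "the series" means these compounds.

Compound 1 `CCOC(=O)c1[nH]c2ccccc2c1C(=O)c1cc(OC)c(OC)c(OC)c1N` and compound 2 `CCOC(=O)c1[nH]c2ccc(Cl)cc2c1C(=O)c1cc(OC)c(OC)c(OC)c1N` share one core, while compound 3 `COc1cc(Cc2c[nH]c3ccccc23)c(N)c(OC)c1OC` is built on another; how the two cores differ is not broken down here. In a functional assay on HT-29 cells (Homo sapiens) for cytotoxicity, read by sulforhodamine B assay, with a stated time of 48 h (on this read-out higher numbers stand for weaker inhibition of growth and lower numbers for stronger inhibition of growth), compound 1 gives 5630 nM. In this assay compound 2 gives 6840 nM. The change between them, (chloro in place of hydrogen on an aromatic carbon), made a 1.2-fold higher number from compound 1 to compound 2 (0.08 log units; within the scatter). In this assay compound 3 reaches only a limit of the assay, > 100000 nM. That value sits at the limit of > 100000 nM in this assay, at which 1 of the 3 values shown sits. Compound 4 `COc1cc(Cc2c[nH]c3ccc(Cl)cc23)c(N)c(OC)c1OC` has not yet been measured; it differs from compound 3 by chloro in place of hydrogen on an aromatic carbon, the same change as between compound 1 and compound 2. Since the measured step stayed within the scatter, the step expected here, a step that the limit leaves unreadable from compound 3 to compound 4, is also expected to be small. Compound 4 is therefore expected to give about 200000 nM in this assay, most likely again only as a limit, because compound 3 itself gives > 100000 nM.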

Compound 4, concentration for 50% growth inhibition: "not active" (no number reported)
The entry for compound 4 holds no number, so the estimate cannot be set against anything.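

No step can be read from compound 3 to compound 4, as compound 4 is reported only as not active, without a number. The compounds shown leave open how far chloro in place of hydrogen shifts growth inhibition on the core of compound 3 in this assay.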